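Removing the tert-butoxycarbonyl cap from compound 2

This account rests on a few compounds, and the source may have more. Where it says the series, first, only, none or still open, it means among the compounds named here.

Compound 2, `CC(C)(C)OC(=O)NCCCCCNC(=O)CN1CN(c2ccccc2)C2(CCN(C(=O)c3ccc(C(C)(C)C)cc3)CC2)C1=O`, gives 13700 nM in an assay on HEK293 cells for displacement of a labelled ligand from NPC1-like intracellular cholesterol transporter 1 (Homo sapiens) (a lower number here means a stronger inhibitor, a higher number a weaker inhibitor), the highest of the three numbers measured. Compound 1, `COC(=O)CCCNC(=O)CN1CN(c2ccccc2)C2(CCN(C(=O)c3ccc(C4CCCCC4)cc3)CC2)C1=O`, gives 2500 nM, and compound 3, `O=C(CN1CN(c2ccccc2)C2(CCN(C(=O)c3ccc(C4CCCCC4)cc3)CC2)C1=O)NCCO`, gives 2000 nM; the step of a 1.3-fold lower number from compound 1 to compound 3 (0.10 log units; within the scatter) shows that swapping the end of the side chain left the number essentially unchanged. Compound 4, `CC(C)(C)c1ccc(C(=O)N2CCC3(CC2)C(=O)N(CC(=O)NCCCCN)CN3c2ccccc2)cc1`, differs from compound 2 by amino in place of ((tert-butoxycarbonyl)amino)methyl on a saturated chain carbon, four bonds along the chain from an amide-type nitrogen. Among the compounds with values here, no measured pair matches this change, since compounds 1 and 2 differ in more than one place. Within the data shown here, the only chain-end step, between compound 1 and compound 3, was small, so the expected step of a 2.0-fold lower number from compound 2 to compound 4 (0.29 log units; within the scatter) is modest at most. Compound 4 is therefore estimated at 7000 nM, within a range from 2000 nM to 25000 nM.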

Compound 4, half-maximal inhibitory concentration: 14500 nM
The estimate for compound 4 lay 2.1-fold (0.32 log units) below the measured number; low and high end bracket the measured number.
By their numbers in this assay, from the lowest: compounds 3 and 1 (each within the scatter of the next); then compounds 2 and 4 (each within the scatter of the next).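

In this assay, the step of a 1.1-fold higher number from compound 2 to compound 4 (0.02 log units; within the scatter) shows that this chain end tolerates a much larger change than the earlier swap did: a group of 9 heavy atoms gives way to amino, a single nitrogen, with no readable shift. Both chain-end steps now lie within the scatter, and neither of the compounds in this step goes against that. Nothing measured here gives a reason for this result. As far as these compounds go, whether a carboxylic acid or a dimethylamine at this chain end would shift the number remains open.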